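Phenylpiperazine Amides and a Dimethylphenyl Replacement

The source may report more compounds than this note shows. Statements on the series, on what has been measured and on what is new or still open speak of the compounds shown alone.

Compound 1 `CC(C)Cc1ccc(C(C)C(=O)N2CCN(c3ccccc3)CC2)cc1` and compound 2 `COc1ccc(N2CCN(C(=O)C(C)c3ccc(CC(C)C)cc3)CC2)cc1` share one amide core and differ only on the aromatic ring that sits on the piperazine nitrogen. In an assay on brain for inhibition of Fatty-acid amide hydrolase 1 (Rattus norvegicus), read by scintillation counting, with a stated time of 10 min (on this read-out lower numbers stand for stronger inhibition and higher numbers for weaker inhibition), compound 1 gives 4700 nM, and compound 2 gives 4500 nM; the step of a 1.0-fold lower number from compound 1 to compound 2 (0.02 log units; within the scatter) lies within the scatter, so the two numbers cannot be told apart. On these two values compound 2 has the lower number, yet it stands level with compound 1 rather than apart from it.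

Compound 3 `Cc1cccc(N2CCN(C(=O)C(C)c3ccc(CC(C)C)cc3)CC2)c1C` carries the change (2,3-dimethylphenyl in place of 4-methoxyphenyl on an amine nitrogen in a ring). Among the compounds with values here, no measured step touches this exact exchange; the only step at hand, from compound 1 to compound 2, changed the same ring by adding a methoxy group and moved nothing beyond the scatter. On that basis the expectation for compound 3 is a step of a 1.1-fold lower number from compound 2 to compound 3 (0.05 log units; within the scatter) in this assay, with no clear direction beyond the scatter. Compound 3 is therefore estimated at 4000 nM, within a range from 1500 nM to 12000 nM.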

Compound 3, half-maximal inhibitory concentration: 1700 nM
Compound 3: the middle estimate sits 2.4-fold (0.37 log units) above what was measured; measured number inside the range.
By their numbers in this assay, from the lowest: compound 3; then compounds 2 and 1 (each within the scatter of the next).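

In this assay, the aromatic group on the amine nitrogen in a ring can shift the number beyond the scatter, which the methoxy change alone had not shown: placing 2,3-dimethylphenyl there in place of 4-methoxyphenyl gives a 2.6-fold lower number from compound 2 to compound 3 (0.42 log units; beyond the scatter), and placing it there in place of phenyl gives a 2.8-fold lower number from compound 1 to compound 3 (0.44 log units; beyond the scatter). Both steps are modest, but since compound 1 and compound 2 stand level, the result reads the same from either of these two groups, and among the three compounds only 2,3-dimethylphenyl sets its compound apart. Nothing in the available evidence bears on the reason for this shift.

Two methyl groups enter together in compound 3, so the compounds shown leave open whether a single one, as in 2-methylphenyl or 3-methylphenyl, would give the same step, and how a chloro or trifluoromethyl group would read at this position. Going by these compounds, the rest of the shared core stays the same in all three compounds, so it also remains open whether the step would hold with a change elsewhere, such as a carboxylic acid in place of the isobutyl group.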